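The source may hold more compounds than are shown below. What is called first, only, known or untested is meant among the compounds shown, and "the series" means these compounds.

Compound 1 `C=C1C(=O)[C@]23C[C@@]1(OCC)CC[C@H]2[C@@]12C=CC(=O)[C@](C)(C(=O)O1)[C@H]2[C@@H]3C(=O)OC` and compound 2 `C=C1C(=O)[C@]23C[C@@]1(OCC)CC[C@H]2[C@@]12C=CC(=O)[C@](C)(C(=O)O1)[C@H]2[C@@H]3C(=O)OCc1ccccc1` share one core and differ only by phenyl in place of hydrogen on a saturated chain carbon bound to an oxygen next to a carbonyl group. In a functional assay on A549 cells (Homo sapiens) for cytotoxicity, read by MTT assay (on this read-out lower numbers stand for stronger inhibition and higher numbers for weaker inhibition), compound 1 gives 18200 nM, and compound 2 gives 24200 nM, which means a 1.3-fold higher number from compound 1 to compound 2 (0.12 log units; within the scatter). Compound 3 `C=C1C(=O)[C@]23C[C@@]1(OC)CC[C@H]2[C@@]12C=CC(=O)[C@](C)(C(=O)O1)[C@H]2[C@@H]3C(=O)OC` carries a second core, which differs from the core of compound 1 by hydrogen in place of methyl on a saturated chain carbon bound to an oxygen on a saturated carbon; in this assay compound 3 gives 54500 nM, and a 3.0-fold higher number from compound 1 to compound 3 (0.48 log units; beyond the scatter). Compound 4 `C=C1C(=O)[C@]23C[C@@]1(OC)CC[C@H]2[C@@]12C=CC(=O)[C@](C)(C(=O)O1)[C@H]2[C@@H]3C(=O)OCc1ccccc1` has not yet been tested; it differs from compound 3 by phenyl in place of hydrogen on a saturated chain carbon bound to an oxygen next to a carbonyl group, the same change as that separating compound 1 and compound 2. Because a 1.3-fold higher number from compound 1 to compound 2 (0.12 log units; within the scatter) stayed within the scatter, compound 4 is expected to stay close to compound 3, with a 1.3-fold higher number from compound 3 to compound 4 (0.11 log units; within the scatter). The estimate for compound 4 in this assay is 70000 nM, expected to lie between 35000 nM and 140000 nM.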

Compound 4, half-maximal inhibitory concentration: 28200 nM
Compound 4: middle estimate off by 2.5-fold (0.39 log units), on the high side; measured number below the stated range.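

Putting benzyloxycarbonyl in place of methoxycarbonyl on the core of compound 3 gives, in this assay, a 1.9-fold lower number from compound 3 to compound 4 (0.29 log units; within the scatter), and this step does not differ measurably from the same change on the core of compound 1: the same change on two cores in this assay, a 1.3-fold higher number (0.12 log units; within the scatter) from compound 1 to compound 2 and a 1.9-fold lower number (0.29 log units; within the scatter) from compound 3 to compound 4, 2.6-fold (0.41 log units) apart, within the scatter of two such steps

Hydrogen in place of methyl on a saturated chain carbon bound to an oxygen on a saturated carbon gives a 1.2-fold higher number from compound 2 to compound 4 (0.07 log units; within the scatter), and this step also agrees with its counterpart within the scatter: the same change on two cores in this assay, a 3.0-fold higher number (0.48 log units; beyond the scatter) from compound 1 to compound 3 and a 1.2-fold higher number (0.07 log units; within the scatter) from compound 2 to compound 4, 2.6-fold (0.41 log units) apart, within the scatter of two such steps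

So neither change is shown to behave differently on the two cores, but two pairs of small steps cannot prove that they behave identically or that this would hold on further cores.

As far as these compounds go, it remains open how a carboxylic acid in place of methoxycarbonyl would read in this assay. The same question applies to a phenyl ring bearing an amine in place of the unsubstituted phenyl.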